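A few compounds are considered here, and "the series" means these few. Any claim that something is new, unique, unknown or untested is made for them only; others in the source may bear on it.

Measured compounds in an assay on isolated protein for agonist activity at Bile acid receptor (Homo sapiens), read by AlphaScreen, with a stated time of 30 min; on this read-out higher numbers stand for an effect only at larger amounts of compound and lower numbers for an effect already at smaller amounts:
- compound 1 `Cc1ccccc1-n1nc(C)c2c1NC(=O)[C@H](C)S[C@@H]2c1ccc(-c2ccoc2)cc1` gives 3500 nM
- compound 2 `CCc1ccccc1-n1nc(C)c2c1NC(=O)[C@H](C)S[C@@H]2c1ccc(Oc2ccccc2)cc1` gives 1100 nM
- compound 3 `COc1cccc(-c2ccc([C@H]3S[C@@H](C)C(=O)Nc4c3c(C)nn4-c3ccccc3C)cc2)c1` gives 1800 nM

The three numbers sit close together. Compound 3 and compound 2 lie within the scatter of each other, and so do compound 3 and compound 1; on the numbers shown, compound 3 is not separated from either neighbour, and the whole set spans a range inside which the assay itself cannot tell the compounds apart.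

Compound 4 `COC(=O)c1cccc(-c2ccc([C@H]3S[C@@H](C)C(=O)Nc4c3c(C)nn4-c3ccccc3C)cc2)c1` is the next member, with methoxycarbonyl in place of methoxy on an aromatic carbon. Going by the values given here, the only measured step at the same place is a 1.9-fold lower number from compound 1 to compound 3 (0.29 log units; within the scatter), where the whole aryl group was exchanged rather than a substituent on it; it stayed within the scatter. Among the compounds with values here, no measured pair exchanges methoxy for methoxycarbonyl, and nothing so far has moved beyond the scatter. A step of no change at the digits printed from compound 3 to compound 4 (within the scatter) is therefore expected, that is, none beyond the scatter. Compound 4 is estimated at 1800 nM, with a range from 700 nM to 4500 nM in this assay.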

Compound 4, half-maximal effective concentration: "not active" (no number reported)
For compound 4 the study gives words and no number, and the estimate cannot be compared.
By their numbers in this assay, from the lowest: compounds 2, 3 and 1 (each within the scatter of the next, the first and the last beyond it).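

In this assay, going by these compounds alone, compound 4 is reported in words only, so no step from compound 3 can be read. No available evidence bears on this result. Still open, from the compounds shown here alone, is how methoxycarbonyl in place of methoxy truly separates compound 4 from compound 3 at 1800 nM.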